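Adding propyl to one side chain of compound 3

A few compounds are considered here, and "the series" means these few. Any claim that something is new, unique, unknown or untested is made for them only; others in the source may bear on it.

In a functional assay on P388 cells (Mus musculus) for cytotoxicity (on this read-out lower numbers stand for stronger inhibition and higher numbers for weaker inhibition), three compounds have numbers so far
- compound 1 `COc1ccc(C[C@H]2C(=O)N[C@@H](C)C(=O)N(C)[C@H]3Cc4ccc(cc4)Oc4cc(ccc4OC)C[C@@H](C(=O)N[C@H](C)C(=O)N[C@@H](CSC(C)=O)C(=O)N2C)N(C)C3=O)cc1` gives 9.77 nM
- compound 2 `COc1ccc(C[C@H]2C(=O)N[C@@H](C)C(=O)N(C)[C@H]3Cc4ccc(cc4)Oc4cc(ccc4OC)C[C@@H](C(=O)N[C@H](C)C(=O)N[C@@H](CC(=O)O)C(=O)N2C)N(C)C3=O)cc1` gives 1200 nM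
- compound 3 `CCN1C(=O)[C@@H](C)NC(=O)[C@@H]2Cc3ccc(OC)c(c3)Oc3ccc(cc3)C[C@@H](C(=O)N2C)N(C)C(=O)[C@H](C)NC(=O)[C@H](Cc2ccc(OC)cc2)N(C)C(=O)[C@@H]1C` gives 43.7 nM

Compound 3 at 43.7 nM holds the middle place of the three, above compound 1 and below compound 2. Compound 4 `CCCCCN1C(=O)[C@@H](C)NC(=O)[C@@H]2Cc3ccc(OC)c(c3)Oc3ccc(cc3)C[C@@H](C(=O)N2C)N(C)C(=O)[C@H](C)NC(=O)[C@H](Cc2ccc(OC)cc2)N(C)C(=O)[C@@H]1C` differs from compound 3 by one change (propyl in place of hydrogen on a saturated chain carbon, two bonds along the chain from an amide-type nitrogen in a ring), propyl in place of hydrogen on a saturated chain carbon, two bonds along the chain from an amide-type nitrogen in a ring. For the measured compounds named here, no measured step covers this change. Going by the values given here, the only one, a 120-fold higher number from compound 1 to compound 2 (2.09 log units; beyond the scatter) with carboxy in place of acetylsulfanyl, is large but shows only that a single change can move the number far. A moderate step to a higher number is expected in this assay (a 2.1-fold higher number from compound 3 to compound 4 (0.31 log units; beyond the scatter)). Compound 4 is estimated at 90 nM with an expected range of 25 nM to 350 nM on this read-out.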

Compound 4, half-maximal inhibitory concentration: 21.4 nM
Beside the measured number, compound 4's estimate is 4.2-fold (0.62 log units) above it; measured number outside the range, below it.
By their numbers in this assay, from the lowest: compound 1; then compound 4; then compound 3; then compound 2.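

In this assay the ethyl of compound 3 extended to pentyl, propyl in place of hydrogen on a saturated chain carbon, gives a 2.0-fold lower number from compound 3 to compound 4 (0.31 log units; beyond the scatter) as a modest change. This position therefore accepts a longer unbranched chain with no loss, and the number moves down rather than up. No available evidence bears on what lies behind this step. As far as these compounds go, whether a still longer chain would lower the number further remains open, as does the outcome for a branched chain or for a chain ending in an amine or a carboxylic acid.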